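The source may report more compounds than this note shows. Statements on the series, on what has been measured and on what is new or still open speak of the compounds shown alone.

Working notes on the series, all read in a functional assay on SGC-7901 cells (Homo sapiens) for inhibition, read by MTT assay, with a stated time of 24 h; on this read-out lower numbers stand for stronger inhibition and higher numbers for weaker inhibition. Compound 1 (`CC1(C)[C@H]2CC[C@]1(C)N(Cc1cn(-c3ccc(C#N)cc3)nn1)C(=O)C2`) gives 500 nM, compound 2 (`CC1(C)[C@H]2CC[C@]1(C)N(Cc1cn(-c3cccc(C#N)c3)nn1)C(=O)C2`) gives 250 nM and compound 3 (`CC1(C)[C@H]2CC[C@]1(C)N(Cc1cn(-c3ccc(O)cc3)nn1)C(=O)C2`) gives 330 nM. Compound 3 is not separated from either of the other two, as a 1.5-fold lower number from compound 1 to compound 3 (0.18 log units; within the scatter) and a 1.3-fold higher number from compound 2 to compound 3 (0.12 log units; within the scatter) both show. The three values therefore form a single group.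

Among the compounds with values here, compound 4 (`Cc1ccc(-n2cc(CN3C(=O)C[C@@H]4CC[C@@]3(C)C4(C)C)nn2)cc1`) keeps the shared core and the triazole-free description is not needed here: the only change is methyl in place of hydroxy on an aromatic carbon, para to a large group (methyl in place of hydroxy on an aromatic carbon). Within the data shown here, no measured compound carries this methyl, so no measured step shows the exchange directly. The closest evidence is the hydroxy in place of cyano exchange, a 1.5-fold lower number from compound 1 to compound 3 (0.18 log units; within the scatter), together with the shift from 4-cyanophenyl to 3-cyanophenyl, a 2.0-fold lower number from compound 1 to compound 2 (0.30 log units; within the scatter). Neither step leaves the scatter, and three compounds are a thin basis. On that evidence, no change beyond the scatter is expected in this assay, in either direction. The expected step is a 1.1-fold higher number from compound 3 to compound 4 (0.03 log units; within the scatter), an estimate that stays within the scatter. For compound 4 the estimated value is 350 nM, with an expected range from 150 nM to 800 nM.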

Compound 4, half-maximal inhibitory concentration: 390 nM
The estimate for compound 4 lay 1.1-fold (0.05 log units) below the measured number, and the stated range covers the measured number.
By their numbers in this assay, from the lowest: compounds 2, 3, 4 and 1 (each within the scatter of the next).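

In this assay, the step of a 1.2-fold higher number from compound 3 to compound 4 (0.07 log units; within the scatter) comes with methyl in place of hydroxy on an aromatic carbon, para to a large group, so at this place a group with 1 hydrogen-bond donor and 1 hydrogen-bond acceptor gives way to one with neither, and the number stays within the scatter. Methyl in place of cyano at the same place, the step of a 1.3-fold lower number from compound 1 to compound 4 (0.11 log units; within the scatter), also stays within the scatter, as does the change to 4-methylphenyl from 3-cyanophenyl, the step of a 1.6-fold higher number from compound 2 to compound 4 (0.19 log units; within the scatter), so compound 4 joins the single group formed by the other three compounds. No measurement at hand accounts for the absence of a separation among these compounds.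

Whether an amine, a carboxylic acid or a longer chain such as butyl in place of the methyl would move the number beyond the scatter remains open, since all four compounds shown fall within one group. The compounds shown also leave open whether the same lack of separation would hold in any read-out other than this assay.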